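This account rests on a few compounds, and the source may have more. Where it says the series, first, only, none or still open, it means among the compounds named here.

Compound 2, whose structure is `Cc1cc(=O)n(-c2cccc(F)c2)nc1C(=O)Nc1ccc(Oc2ncnc3c2ccn3C)cc1`, was tested in a functional assay on MCF7 cells (Homo sapiens) for cytotoxicity, read by MTT assay, with a stated time of 72 h (on this read-out lower numbers stand for stronger inhibition and higher numbers for weaker inhibition), where compound 2 gives 30800 nM. Among the compounds with values here, only one other compound has been measured alongside it: compound 1, with the structure `Cc1ccc(-n2nc(C(=O)Nc3ccc(Oc4ncnc5[nH]ccc45)cc3)c(C)cc2=O)cc1`. In this assay compound 1 gives 3620 nM. Of these two numbers, the number for compound 2 is the higher one, and the gap between the two compounds is wider than the usual scatter of repeated measurements.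

The next compound, compound 3, has the structure `Cc1ccc(-n2nc(C(=O)Nc3ccc(Oc4ncnc5c4ccn5C)cc3)c(C)cc2=O)cc1`. It keeps the whole of compound 2 except for one exchange: 4-methylphenyl in place of 3-fluorophenyl on an aromatic nitrogen. Within the data shown here, no single-change pair among the measured compounds shows what this exchange alone does. Compound 1 carries the same 4-methylphenyl group, but it also differs from compound 3 elsewhere in the shared core, so its lower number cannot be credited to the phenyl group alone.

Compound 3 is therefore expected to give a lower number than compound 2, with the step from compound 2 to compound 3 estimated at a 3.1-fold lower number from compound 2 to compound 3 (0.49 log units; beyond the scatter). The estimate for compound 3 in this assay is 10000 nM, within a range from 3000 nM to 35000 nM.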

Compound 3, half-maximal inhibitory concentration: 10800 nM
The estimate for compound 3 lay 1.1-fold (0.03 log units) below the measured number; the measured number falls inside the stated range.
By their numbers in this assay, from the lowest: compound 1; then compound 3; then compound 2.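

Exchanging 3-fluorophenyl for 4-methylphenyl on the aromatic nitrogen, with the rest of the molecule unchanged, gives in this assay a 2.9-fold lower number from compound 2 to compound 3 (0.46 log units; beyond the scatter) and so shows that this position alone can move the number beyond the scatter. The second single change, methyl in place of hydrogen on an aromatic nitrogen of the shared core, gives a 3.0-fold higher number from compound 1 to compound 3 (0.47 log units; beyond the scatter) and shows that this site matters too, with the hydrogen giving the lower number and the methyl the higher one. The compounds offer no independent measurement that could explain either shift.

The phenyl exchange removes a fluorine, adds a methyl and changes where the substituent sits, all at once, so 3-methylphenyl and 4-fluorophenyl would be needed to tell these parts apart. Going by these compounds, it also remains open whether the phenyl exchange gives a similar step when hydrogen rather than methyl sits on the core nitrogen, and whether a longer chain such as ethyl on that nitrogen, or an amine on the phenyl ring, would push the number further in either direction.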